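Bromo to methoxy, starting from an assay limit

The source may report more compounds than this note shows. Statements on the series, on what has been measured and on what is new or still open speak of the compounds shown alone.

In a functional assay on HCT-116 cells (Homo sapiens) for inhibition, read by CCK-8 assay, with a stated time of 48 h (a lower number here means a stronger inhibitor, a higher number a weaker inhibitor), compound 1 (`COc1ccc(CN(C(=O)CSC(=S)N2CCN(C(C)=O)CC2)c2cc(OC)c(OC)c(OC)c2)cc1`) reads 1370 nM in this test, and compound 2 (`COc1ccc(CN(C(=O)CSC(=S)N2CCc3ccccc3C2)c2cc(OC)c(OC)c(OC)c2)cc1`) reads 15900 nM in the same test. For the measured compounds named here, the one measured step is a 12-fold higher number from compound 1 to compound 2 (1.06 log units; beyond the scatter) and is large, beyond the scatter. Compound 3 (`COc1ccc(CN(C(=O)CSC(=S)N2CCN(C(=O)OC(C)(C)C)CC2)c2ccc(Br)cc2)cc1`) has no number, only a limit of the assay, which is > 20000 nM as reported. From the compounds shown here alone, compound 3 therefore stands at the limit of > 20000 nM in this assay, at which 1 of the 3 values shown sits, and its true distance from the others is unknown.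

Compound 4 (`COc1ccc(CN(C(=O)CSC(=S)N2CCN(C(=O)OC(C)(C)C)CC2)c2ccc(OC)cc2)cc1`) carries methoxy in place of bromo on an aromatic carbon, para to a large group (methoxy in place of bromo on an aromatic carbon). Going by the values given here, no measured step touches that place. The step of a 12-fold higher number from compound 1 to compound 2 (1.06 log units; beyond the scatter) concerns the group on the thiocarbonyl carbon, so it bears only indirectly, showing that one change can move a compound of this series a long way. With compound 3 at > 20000 nM as a limit, the only open direction that can be read as a number is downward, and a modest move is expected, or none visible at all. The expected step in this assay is an at least 1.2-fold lower number from compound 3 to compound 4 (0.09 log units; that floor lies within the scatter) as a rough estimate. For compound 4 the estimate is 16000 nM within an expected range of 5000 nM to 40000 nM overall.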

Compound 4, half-maximal inhibitory concentration: > 20000 nM
Compound 4: a limit, no number; the forecaster's own chance of this, stated with the estimate: 45%; middle value at least 1.2-fold (0.09 log units) from the limit.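

Compound 3 and compound 4 are each reported in this assay only as a limit, not as a number, so no step can be read between them: the limit of > 20000 nM in this assay, at which 2 of the 4 values shown sit.

The compounds shown leave open whether methoxy in place of bromo changes the reading at all, and in which direction.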